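A few compounds are considered here, and "the series" means these few. Any claim that something is new, unique, unknown or untested is made for them only; others in the source may bear on it.

Compound 1 `COc1c(N2C[C@H]3CCCN(C(=O)Cn4cc(CN5C(=O)C(=O)c6ccccc65)nn4)[C@H]3C2)c(F)cc2c(=O)c(C(=O)O)cn(C3CC3)c12` and compound 2 `COc1c(N2C[C@H]3CCCN(C(=O)Cn4cc(CN5C(=O)C(=O)c6cc(F)ccc65)nn4)[C@H]3C2)c(F)cc2c(=O)c(C(=O)O)cn(C3CC3)c12` share one core; compound 3 `COc1c(N2C[C@H]3CCCN(C(=O)Cn4cc(CN5C(=O)/C(=N/NC(N)=S)c6ccccc65)nn4)[C@H]3C2)c(F)cc2c(=O)c(C(=O)O)cn(C3CC3)c12` and compound 4 `COc1c(N2C[C@H]3CCCN(C(=O)Cn4cc(CN5C(=O)/C(=N/NC(N)=S)c6cc(F)ccc65)nn4)[C@H]3C2)c(F)cc2c(=O)c(C(=O)O)cn(C3CC3)c12` share another, and the difference between the two cores is not broken down here. In an ADME assay on Vero cells (Chlorocebus sabaeus) for cytotoxicity, read by MTT assay, with a stated time of 72 h (a lower number here means that less compound is tolerated, a higher number that more compound is tolerated), compound 1 gives 32 ug/mL, and compound 2 gives 16 ug/mL. Among the measured compounds shown here, the single change between them, (fluoro in place of hydrogen on an aromatic carbon), made a 2.0-fold lower number from compound 1 to compound 2 (0.30 log units; within the scatter). In this assay compound 3 gives 16 ug/mL, level with compound 2. Compound 4 carries the same change against compound 3, (fluoro in place of hydrogen on an aromatic carbon), at the same place. The step of a 2.0-fold lower number from compound 1 to compound 2 (0.30 log units; within the scatter) stayed within the scatter. On that ground a step of about the same size is expected for compound 4, namely a 1.5-fold lower number from compound 3 to compound 4 (0.16 log units; within the scatter). Compound 4 is thus estimated at 11 ug/mL in this assay, with a likely range from 5 ug/mL to 25 ug/mL.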

Compound 4, half-maximal cytotoxic concentration: 8 ug/mL
Compound 4: the middle estimate sits 1.4-fold (0.14 log units) above what was measured, and the stated range covers the measured number.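

In this assay, fluoro in place of hydrogen on an aromatic carbon gives a 2.0-fold lower number from compound 3 to compound 4 (0.30 log units; within the scatter), and the two cores can be set side by side for this change: the same change on two cores in this assay, a 2.0-fold lower number (0.30 log units; within the scatter) from compound 1 to compound 2 and a 2.0-fold lower number (0.30 log units; within the scatter) from compound 3 to compound 4, 1.0-fold (0.00 log units) apart, within the scatter of two such steps
On these two cores, then, the change carries over with a step of the same size. Each step lies within the scatter, however, so this agreement does not show that the fluoro has a real effect on how much compound the cells tolerate, and two cores cannot show how the change would behave on any other core in the series.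

The compounds shown leave open whether a different group at the same place, such as chloro, methoxy or an amine, would give a step beyond the scatter. They also leave open whether fluoro elsewhere on this ring would behave alike.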